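This account rests on a few compounds, and the source may have more. Where it says the series, first, only, none or still open, it means among the compounds named here.

Going by the values given here, compound 1 `Cc1cc(NCc2ccccn2)n2ncc(Br)c2n1` is the one member of this pair of measured compounds that returns an actual number in a physicochemical assay for solubility, read by HPLC, using the shake flask method, measured as kinetic solubility, with a stated time of 2 h, at pH 7.4 (on this read-out higher numbers stand for higher solubility and lower numbers for lower solubility), where compound 1 gives 89300 nM. Compound 2 `Cc1cc(Nc2ccccn2)n2nc(C)c(-c3ccccc3)c2n1` is reported in this assay only as a limit, < 5000 nM, and not as a number; the limit of < 5000 nM in this assay, at which 1 of the 2 values shown sits, marks where that limit sits. The two measured compounds differ in more than one place. Among the compounds with values here, no single step between them can be drawn, and only what each value shows can be stated.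

Compound 3 `Cc1cc(NCc2ccccn2)n2ncc(C3=CCOCC3)c2n1` is not yet measured in this assay. It differs from compound 1 in one place (a group of 6 heavy atoms (5 carbon, 1 oxygen; one six-membered non-aromatic ring with 1 hetero atom) in place of one bromine atom, on an aromatic carbon). The change is on an aromatic carbon of a five-membered aromatic ring with two nitrogen, part of a fused system of two rings, two ring bonds from the ring nitrogen.

Within the data shown here, no measured step guides this change, so the step from compound 1 to compound 3 in this assay is expected to be modest, a 1.5-fold lower number from compound 1 to compound 3 (0.17 log units; within the scatter), most likely within or only slightly beyond the usual scatter and, if anything, downward. Compound 3 is accordingly estimated at 60000 nM, with a range from 15000 nM to 200000 nM.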

Compound 3, solubility: 171000 nM
The estimate for compound 3 lay 2.9-fold (0.45 log units) below the measured number, and the stated range covers the measured number.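

Going by these compounds alone, on an aromatic carbon of the five-membered aromatic ring with 2 nitrogen, two ring bonds from the ring nitrogen, the earlier compounds offered no step, and the exchange of bromo for a group of 6 heavy atoms now supplies one: in this assay the result is a 1.9-fold higher number from compound 1 to compound 3 (0.28 log units; within the scatter). As this step lies within the scatter, the reading does not separate the two compounds, even though the entering group brings a six-membered non-aromatic ring with 1 hetero atom, a double bond outside aromatic rings and a hydrogen-bond acceptor that bromo does not have. Nothing in the data shown gives a cause for this step.

Going by these compounds, whether an amine, a carboxylic acid, a morpholine or a longer chain on this same carbon would give a step beyond the scatter remains open. On these data alone, with a single step at this position, it also remains open whether the double bond or the ring oxygen of the entering group has any bearing on the read-out, and whether the same exchange would read alike on another core.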